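Replacing 4-hydroxyphenyl with 2-nitrophenyl on a shared core

The source may hold more compounds than are shown below. What is called first, only, known or untested is meant among the compounds shown, and "the series" means these compounds.

Measured in a functional assay on SW-620 cells (Homo sapiens) for cytotoxicity, read by sulforhodamine B assay, with a stated time of 48 h; a lower number here means a stronger inhibitor, a higher number a weaker inhibitor:
- compound 1 `C[C@H]1CC[C@@H]2[C@@H](OC(=O)[C@]23CC(c2ccc(Cl)cc2)=NO3)[C@]2(C)C(=O)C=C[C@@]12O`: 51000 nM
- compound 2 `C[C@H]1CC[C@@H]2[C@@H](OC(=O)[C@]23CC(c2ccccc2)=NO3)[C@]2(C)C(=O)C=C[C@@]12O`: 45400 nM
- compound 3 `C[C@H]1CC[C@@H]2[C@@H](OC(=O)[C@]23CC(c2ccc(O)cc2)=NO3)[C@]2(C)C(=O)C=C[C@@]12O`: 89000 nM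

In this assay, compound 3 at 89000 nM cannot be told apart from the other two compounds, as its steps show: a 1.7-fold higher number from compound 1 to compound 3 (0.24 log units; within the scatter) and a 2.0-fold higher number from compound 2 to compound 3 (0.29 log units; within the scatter). The remaining measured step is a 1.1-fold lower number from compound 1 to compound 2 (0.05 log units; within the scatter). All three steps exchange one group on the aromatic ring while the core stays the same, so they are the closest guide available.

Compound 4 `C[C@H]1CC[C@@H]2[C@@H](OC(=O)[C@]23CC(c2ccccc2[N+](=O)[O-])=NO3)[C@]2(C)C(=O)C=C[C@@]12O` has 2-nitrophenyl in place of 4-hydroxyphenyl on a carbon with a double bond to nitrogen. Going by the values given here, no measured compound carries a nitro group, so this guide is only indirect. Since the steps among compound 1, compound 2 and compound 3 stayed within the scatter, no step beyond the scatter is expected here. The expected change is a 1.5-fold lower number from compound 3 to compound 4 (0.19 log units; within the scatter). For compound 4 the estimated value is 58000 nM, with an expected range from 26000 nM to 125000 nM.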

Compound 4, half-maximal inhibitory concentration: 40000 nM
Estimate against measurement, compound 4: 1.5-fold (0.16 log units) above; low and high end bracket the measured number.
By their numbers in this assay, from the lowest: compounds 4, 2, 1 and 3 (each within the scatter of the next, the first and the last beyond it).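

In this assay, going by these compounds alone, the exchange of 4-hydroxyphenyl for 2-nitrophenyl gives a 2.2-fold lower number from compound 3 to compound 4 (0.35 log units; beyond the scatter) and is the first step at this position to pass beyond the scatter, though only modestly. The same 2-nitrophenyl group cannot be told apart from the plain phenyl or the 4-chlorophenyl group, with a 1.1-fold lower number from compound 2 to compound 4 (0.05 log units; within the scatter) and a 1.3-fold lower number from compound 1 to compound 4 (0.11 log units; within the scatter) both staying within the scatter, so the one clear gap is confined to the pair of compound 3 and compound 4. Nothing in the data at hand accounts for that gap.

On these data alone, what an amine or a carboxylic acid on this aromatic ring would do remains open, as does replacing the ring with a longer chain. As far as these compounds go, it is also open whether any change at this position can move the number far outside this narrow spread.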